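Methyl to Methylsulfanyl: What the Next Dose Might Be

The compounds below may be only part of what the source reports. "The series", "measured", "known", "first", "only" and "open" are said of these compounds alone.

Measured so far in a functional assay on the whole organism (strain Sprague-Dawley) for inhibition, with Rattus norvegicus as the target; on this read-out higher numbers stand for an effect only at larger amounts of compound and lower numbers for an effect already at smaller amounts:
Compound 1, `O=c1c(-c2nn[nH]n2)c[nH]c2ccccc12`: in this assay compound 1 gives > 20 mg/kg, which is a limit of the assay, not a number.
Compound 2, `COc1cccc2c(=O)c(-c3nn[nH]n3)c[nH]c12`: in this assay compound 2 gives 0.312 mg/kg.
Compound 3, `Cc1cccc2c(=O)c(-c3nn[nH]n3)c[nH]c12`: in this assay compound 3 gives > 10 mg/kg, again a limit of the assay rather than a number.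

Compound 3 therefore stands at a limit, and compound 1 stands at a second limit; only compound 2 has a true number. Compound 4, `CSc1cccc2c(=O)c(-c3nn[nH]n3)c[nH]c12`, has not yet been measured. It differs from compound 3 by one change: methylsulfanyl in place of methyl on an aromatic carbon.

Within the data shown here, two measured steps bear on this. There is an at least 64-fold lower number from compound 1 to compound 2 (1.80 log units; beyond the scatter), and there is an at least 32-fold higher number from compound 2 to compound 3 (1.50 log units; beyond the scatter). Both are large, and both turn on the group sitting at the same position: a methoxy gives a small dose, a methyl gives only a limit. Methylsulfanyl carries the same count of one hydrogen-bond acceptor as methoxy, so an improvement from compound 3 is expected, though its size is uncertain. The expected step is an at least 5.0-fold lower number from compound 3 to compound 4 (0.69 log units; beyond the scatter). Compound 4 is estimated to give 2 mg/kg, between 0.3 mg/kg and 20 mg/kg.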

Compound 4, minimum effective dose: 25 mg/kg
Beside the measured number, compound 4's estimate is 13-fold (1.10 log units) below it; the measured number lies above the stated range.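

In this assay, the acceptor count alone does not settle the outcome at this position: methylsulfanyl and methoxy each bring one hydrogen-bond acceptor, yet there is an 80-fold higher number from compound 2 to compound 4 (1.90 log units; beyond the scatter). Exchanging the oxygen of methoxy for sulfur is therefore enough to lose the low dose, and among the four compounds only compound 2 reaches one. The steps to compound 4 from compound 1 and from compound 3 cannot be read: each starts from a limit of the assay, not a number.

As far as these compounds go, it remains open whether the low dose of compound 2 would survive in ethoxy, a longer chain on the same oxygen. Also open, from the compounds shown here alone, is what an amine or a fluorine on this aromatic carbon would give.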